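The compounds below may be only part of what the source reports. "The series", "measured", "known", "first", "only" and "open" are said of these compounds alone.

Measured compounds, with intrinsic clearance in an ADME assay on microsomes from liver (Homo sapiens) for metabolic stability, read by LC-MS, using NADPH, with stated times of 5 min and 30 min, tested at 1 uM; on this read-out higher numbers stand for fast clearance and lower numbers for slow clearance:
- compound 1, `CN(C)C(=O)c1cc(-c2cnc(NCc3c(F)ccc4c3CCO4)c3cn[nH]c(=O)c23)n(C)n1`, gives 21 mL.min-1.g-1
- compound 2, `CNC(=O)c1cc(-c2cnc(NCc3c(F)ccc4c3CCO4)c3cn[nH]c(=O)c23)n(C)n1`, gives < 3 mL.min-1.g-1, which is a limit of the assay and not a number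
- compound 3, `Cn1nccc1-c1cnc(NCc2c(F)ccc3c2CCO3)c2cn[nH]c(=O)c12`, gives 14 mL.min-1.g-1

Compound 3 stands at the lower of the two numbers in this assay, and its nearest neighbour is compound 1, with a 1.5-fold lower number from compound 1 to compound 3 (0.18 log units; within the scatter). Compound 2 sits at the limit of < 3 mL.min-1.g-1 in this assay, at which 1 of the 3 values shown sits. The other two steps, an at least 7.0-fold lower number from compound 1 to compound 2 (0.84 log units; beyond the scatter) and an at least 4.6-fold higher number from compound 2 to compound 3 (0.66 log units; beyond the scatter), both concern the carbamoyl group on the shared core: hydrogen in place of methyl on an amide-type nitrogen, and hydrogen in place of methylcarbamoyl on an aromatic carbon.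

Compound 4, `CC(=O)N1CCC(c2cnc(NCc3c(F)ccc4c3CCO4)c3cn[nH]c(=O)c23)CC1`, differs from compound 3 by 1-acetylpiperidin-4-yl in place of 1-methyl-1H-pyrazol-5-yl on an aromatic carbon. Among the measured compounds shown here, no measured step exchanges the 1-methyl-1H-pyrazol-5-yl ring itself; all three leave that ring in place and alter only what is attached to it. They therefore give no direct guide to a 1-acetylpiperidin-4-yl in its place. The step of a 1.1-fold higher number from compound 3 to compound 4 (0.03 log units; within the scatter) is expected to stay within the scatter. Compound 4 is estimated at 15 mL.min-1.g-1. The range for compound 4 is expected to run from 6 mL.min-1.g-1 to 40 mL.min-1.g-1.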

Compound 4, intrinsic clearance in microsomes: 207 mL.min-1.g-1
The estimate for compound 4 lay 14-fold (1.14 log units) below the measured number, and the stated range ends below it.
By their numbers in this assay, from the lowest: compounds 3 and 1 (each within the scatter of the next); then compound 4. At a limit, below all of these: compound 2.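

At this place, on an aromatic carbon of the shared core, exchanging the ring itself has a large effect in this assay: 1-acetylpiperidin-4-yl in place of 1-methyl-1H-pyrazol-5-yl gives a 15-fold higher number from compound 3 to compound 4 (1.17 log units; beyond the scatter). The same exchange also raises the number against both carbamoyl-bearing rings, with a 9.9-fold higher number from compound 1 to compound 4 (0.99 log units; beyond the scatter) and an at least 69-fold higher number from compound 2 to compound 4 (1.83 log units; beyond the scatter), so compound 4 stands beyond the scatter of all three earlier compounds, whereas those compounds all keep the 1-methyl-1H-pyrazol-5-yl ring. The step from compound 2 starts from a limit of the assay and not a number: the limit of < 3 mL.min-1.g-1 in this assay, at which 1 of the 4 values shown sits.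

One exchange cannot separate the contribution of the acetyl group from that of the non-aromatic ring. On these data alone, whether a piperidin-4-yl ring with a free amine, or a phenyl ring, would fall nearer compound 3 or compound 4 remains open.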